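A few compounds are considered here, and "the series" means these few. Any claim that something is new, unique, unknown or untested is made for them only; others in the source may bear on it.

Measured so far:
Compound 1 `O=C1C2=C(C(=O)c3ncccc31)C1(CS2)NC(=O)N(c2ccc(Cl)cc2)C1=O`, in a functional assay on HT-29 cells (Homo sapiens) for antiproliferative activity, read by MTT assay, with a stated time of 96 h (on this read-out higher numbers stand for weaker inhibition and lower numbers for stronger inhibition), compound 1 gives 2 nM.
Compound 2 `O=C1C2=C(C(=O)c3ncccc31)C1(CS2)NC(=O)N(c2ccc([N+](=O)[O-])cc2)C1=O`, in this assay compound 2 gives 250 nM.

Going by the values given here, compound 2 stands at the highest of the two numbers; its only neighbour is compound 1, and the single recorded step, a 130-fold higher number from compound 1 to compound 2 (2.10 log units; beyond the scatter), is large and beyond the scatter.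

Compound 3 `O=C1C2=C(C(=O)c3ncccc31)C1(CS2)NC(=O)N(c2ccncc2)C1=O` is still to be measured. The change from compound 2 is pyridin-4-yl in place of 4-nitrophenyl on an amide-type nitrogen in a ring. Among the compounds with values here, the one measured step bears on it only as a precedent: it shows that exchanging the group on the amide-type nitrogen in the ring can shift this assay by a large amount. Within the data shown here, for pyridin-4-yl itself no measured counterpart exists, so the direction rests on that precedent alone. A step of a 6.3-fold lower number from compound 2 to compound 3 (0.80 log units; beyond the scatter) is expected, with wide uncertainty. Compound 3 is estimated at 40 nM, within a range of 4 nM to 400 nM.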

Compound 3, half-maximal inhibitory concentration: 2 nM
Compound 3: the middle estimate sits 20-fold (1.30 log units) above what was measured; the measured number lies below the stated range.
By their numbers in this assay, from the lowest: compounds 1 and 3 (each within the scatter of the next); then compound 2.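

In this assay, the low number at the amide-type nitrogen in the ring is not confined to 4-chlorophenyl: pyridin-4-yl in its place gives no change at the digits printed from compound 1 to compound 3 (within the scatter) and so stands level with it. Going by these compounds alone, a six-membered aromatic ring with one hetero atom therefore serves here as well as a chlorinated ring of carbon only, while a 130-fold lower number from compound 2 to compound 3 (2.10 log units; beyond the scatter) leaves 4-nitrophenyl as the only one of the three groups with the higher number. Nothing measured on these compounds accounts for this split.

Open, as far as these compounds go, is whether a 4-aminophenyl or 4-carboxyphenyl group would fall with compound 1 and compound 3 or with compound 2. Also open, from the compounds shown here alone, is whether pyridin-3-yl, pyridin-2-yl or unsubstituted phenyl would hold the low number seen with pyridin-4-yl.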